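Weak topoisomerase 1 inhibitors: swapping a chain for a ring

The compounds below may be only part of what the source reports. "The series", "measured", "known", "first", "only" and "open" are said of these compounds alone.

Compounds measured so far:
- compound 1 `CNCCCNc1c(F)cc2c(=O)c(C(=O)O)cn(Cc3ccc(-c4ccccc4)cc3)c2c1OC`: 101000 nM
- compound 2 `CNC(=O)c1cn(Cc2ccc(-c3ccccc3)cc2)c2c(OC)c(N3CC[C@@H](CN)C3)c(F)cc2c1=O`: 82100 nM
- compound 3 `O=C(O)c1cn(Cc2ccc(-c3ccccc3)cc2)c2cc(N3CC4CNCC4C3)c(F)cc2c1=O`: 33300 nM

All three were run in an assay on isolated protein for inhibition of DNA topoisomerase 1 (Homo sapiens), with a stated time of 15 min; a lower number here means a stronger inhibitor, a higher number a weaker inhibitor. In this assay compound 1 gives 101000 nM, the highest number of the three. Compound 2, with 82100 nM, sits within the scatter of compound 1, so the two cannot be told apart. Compound 3, with 33300 nM, gives a lower number than compound 1, and that gap lies beyond the scatter. All three remain weak inhibitors.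

The step under consideration leads from compound 1 to compound 4 `COc1c(N2CC[C@@H](C(N)=O)C2)c(F)cc2c(=O)c(C(=O)O)cn(Cc3ccc(-c4ccccc4)cc3)c12`. The structural change is 3-carbamoylpyrrolidin-1-yl in place of (3-(methylamino)propyl)amino on an aromatic carbon. The acid, the methoxy group and the fluoro group of compound 1 are kept; only the substituent on the aromatic carbon described above is exchanged.

For the measured compounds named here, no step between measured compounds matches this exchange, so nothing measured bears on it directly. Compound 2 carries a pyrrolidine ring at the same place and gives 82100 nM, which is indistinguishable from compound 1. On that basis the step from compound 1 to compound 4 is expected to be small, a 1.2-fold lower number from compound 1 to compound 4 (0.07 log units; within the scatter), not beyond the scatter in either direction.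

Compound 4 is therefore estimated at 85000 nM, with a range from 30000 nM to 220000 nM.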

Compound 4, half-maximal inhibitory concentration: > 200000 nM
Compound 4: no number, only a limit; the forecaster's own chance of this, stated with the estimate: 15%; middle value at least 2.3-fold (0.37 log units) away from the limit.
By their numbers in this assay, from the lowest: compound 3; then compounds 2 and 1 (each within the scatter of the next). At a limit, above all of these: compound 4.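

In this assay compound 4 gives > 200000 nM, which is a limit and not a number. With 3-carbamoylpyrrolidin-1-yl in place of (3-(methylamino)propyl)amino on this aromatic carbon, ortho to the fluoro and methoxy groups, the series records an at least 1.9-fold higher number from compound 1 to compound 4 (0.29 log units; that floor lies within the scatter), so this exchange gives no lower number on the core of compound 1, although the floor of the step alone does not establish a loss beyond the scatter. Replacing the open chain with this ring therefore offers no route to a stronger inhibitor at this place, and the step has a floor but no measured size: the limit of > 200000 nM in this assay, at which 1 of the 4 values shown sits.

On these data alone, how far compound 4 really lies from compound 1 remains open, and so does whether the ring or its carbamoyl group accounts for the step, as the two enter together in this single exchange. Also open, as far as these compounds go, is whether 3-aminopyrrolidin-1-yl, which carries an amine on the ring where compound 4 carries the carbamoyl group, would give a number lower than that of compound 1 on the same acid, methoxy and fluoro core.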